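Closing the Urea Tail into a Substituted Pyrrolidine Ring

The source may report more compounds than this note shows. Statements on the series, on what has been measured and on what is new or still open speak of the compounds shown alone.

Measured so far:
Compound 1: `O=C(NCc1ccc(C(=O)N2CCCCc3ccccc32)c(Cl)c1)Nc1c(F)cccc1F`, 40 nM
Compound 2: `Cc1cc(C(=O)N2CCCCc3ccccc32)ccc1CNC(=O)NCC(=O)N(C)C`, 58 nM

Both compounds were tested in a functional assay on HEK293 cells for agonist activity at Vasopressin V2 receptor (Homo sapiens), read by a luciferase reporter and cAMP accumulation; on this read-out lower numbers stand for an effect already at smaller amounts and higher numbers for an effect only at larger amounts of compound. In this assay compound 1 gives 40 nM, and compound 2 gives 58 nM. Within the data shown here, on these two numbers compound 2 and compound 1 lie within the scatter of each other, so neither stands apart from the other; with only two measured compounds there is no step to draw a trend from.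

Compound 3, `CO[C@@H]1C[C@@H](C(=O)N(C)C)N(C(=O)NCc2ccc(C(=O)N3CCCCc4ccccc43)cc2C)C1`, has not yet been measured in this assay. It differs from compound 2 in a single place: 2-(dimethylcarbamoyl)-4-methoxypyrrolidin-1-yl in place of ((dimethylcarbamoyl)methyl)amino on a carbonyl carbon. The open chain that carried a hydrogen-bond donor is replaced by a five-membered ring that carries none, and two defined stereocentres are introduced. Among the measured compounds shown here, no measured pair shows a change of this kind, so the direction of the step rests on expectation alone. Compound 3 is expected to land close to compound 2, with at most a modest move toward larger amounts, a step of a 1.6-fold higher number from compound 2 to compound 3 (0.19 log units; within the scatter) in this assay. The estimate for compound 3 is 90 nM, with a range from 25 nM to 350 nM.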

Compound 3, half-maximal effective concentration: 4.7 nM
Estimate against measurement, compound 3: 19-fold (1.28 log units) above; measured number below the stated range.
By their numbers in this assay, from the lowest: compound 3; then compounds 1 and 2 (each within the scatter of the next).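

In this assay the group on the carbonyl carbon turns out to be a place where one change can move the result a long way, with a 12-fold lower number from compound 2 to compound 3 (1.09 log units; beyond the scatter) as the open ((dimethylcarbamoyl)methyl)amino gives way to 2-(dimethylcarbamoyl)-4-methoxypyrrolidin-1-yl. The leaving group counts one hydrogen-bond donor and the entering group counts none, which shows that a donor in this group is not needed for an effect at small amounts of compound. Nothing measured here accounts for the size of this step.

This single step also bundles several changes together: the closed five-membered ring, the lost donor, the added methoxy group and the two defined stereocentres, and the compounds shown cannot tell which of these carries the gain. On these data alone, it stays open whether a hydroxyl group or an amine in place of the methoxy group, or the mirror-image arrangement at the two stereocentres, would keep a number as low as that of compound 3.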